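Inverting a Ring Stereocentre: From Compound 3 to Compound 4

The source may hold more compounds than are shown below. What is called first, only, known or untested is meant among the compounds shown, and "the series" means these compounds.

Measured compounds:
compound 1 `CCCCC[C@@H](C[C@H](O)C[C@@H]1CC=CC(=O)O1)OC`: 35400 nM
compound 2 `CCCCC[C@H](C[C@@H](O)C[C@H]1CC=CC(=O)O1)OC`: 28900 nM
compound 3 `CCCCC[C@@H](C[C@@H](O)C[C@@H]1CC=CC(=O)O1)OC`: 49400 nM

In a functional assay on A2780 cells (Homo sapiens) for cytotoxicity, read by MTT assay, with a stated time of 24 h (a higher number here means a weaker inhibitor, a lower number a stronger inhibitor), compound 3 gives the highest of the three numbers, but the two steps that reach it, a 1.4-fold higher number from compound 1 to compound 3 (0.14 log units; within the scatter) and a 1.7-fold higher number from compound 2 to compound 3 (0.23 log units; within the scatter), both lie within the scatter, as does a 1.2-fold lower number from compound 1 to compound 2 (0.09 log units; within the scatter). The three stereoisomers are therefore indistinguishable on these data.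

Compound 4 `CCCCC[C@@H](C[C@@H](O)C[C@H]1CC=CC(=O)O1)OC` differs from compound 3 in this way: the two compounds have the same atoms and bonds and differ only in configuration as drawn: 1 of 3 stereo elements differ; a stereocentre at a saturated ring carbon is drawn S in compound 3 and R in compound 4. A change of a stereocentre at a saturated ring carbon is already contained in a 1.7-fold higher number from compound 2 to compound 3 (0.23 log units; within the scatter), and every centre is inverted in a 1.2-fold lower number from compound 1 to compound 2 (0.09 log units; within the scatter), without any step beyond the scatter. No shift beyond the scatter is expected here either. Compound 4 is estimated at 36000 nM, within 16000 nM to 80000 nM, an expected step of a 1.4-fold lower number from compound 3 to compound 4 (0.14 log units; within the scatter).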

Compound 4, half-maximal inhibitory concentration: 33700 nM
The estimate for compound 4 lay 1.1-fold (0.03 log units) above the measured number; measured number inside the range.
By their numbers in this assay, from the lowest: compounds 2, 4, 1 and 3 (each within the scatter of the next).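

In this assay, for the compounds shown here, inverting the saturated ring carbon alone, with the other two stereocentres unchanged, gives a 1.5-fold lower number from compound 3 to compound 4 (0.17 log units; within the scatter), the first step to isolate this centre. A single chain stereocentre gives a 1.2-fold higher number from compound 2 to compound 4 (0.07 log units; within the scatter), and a chain and the ring stereocentre together give a 1.1-fold lower number from compound 1 to compound 4 (0.02 log units; within the scatter). Neither a single nor a paired inversion therefore leaves the scatter among these four stereoisomers: the fact that compounds 3 and 4 differ only in the configuration as drawn

All four compounds share the same atoms and bonds, so the shown data say nothing about changes other than configuration. Going by these compounds, whether an amine in place of the hydroxyl, or a longer chain, would move the number beyond the scatter stays open.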